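Trifluoromethyl on the diethylamino core: an expected inhibition

The source may report more compounds than this note shows. Statements on the series, on what has been measured and on what is new or still open speak of the compounds shown alone.

Compound 1, `Cc1ccc2nc(-c3ccccc3C(F)(F)F)[nH]c(=O)c2c1`: 21.1%
Compound 2, `CCN(CC)c1ccc2nc(-c3ccccc3OC(F)(F)F)[nH]c(=O)c2c1`: 0%
Compound 3, `CCN(CC)c1ccc2nc(-c3ccccc3N(C)C)[nH]c(=O)c2c1`: 0%

Three compounds share one core and differ in the group on the six-membered aromatic ring of carbon only and in the group on the core. In an assay on isolated protein for inhibition of DNA topoisomerase 1 (Homo sapiens), with a stated time of 30 min, tested at 20 uM (a lower number here means a weaker effect, a higher number a stronger effect of the compound at the concentration tested), compound 1 gives 21.1%. Compound 2 gives 0% in this assay, and compound 3 gives 0%. Compound 3 stands level with compound 2, the two together the lowest of the three readings, while compound 1 sits higher by an amount beyond the scatter. Within the data shown here, the only step within this set is no change at the digits printed from compound 2 to compound 3 (within the scatter).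

Compound 4, `CCN(CC)c1ccc2nc(-c3ccccc3C(F)(F)F)[nH]c(=O)c2c1`, follows from compound 3 by trifluoromethyl in place of dimethylamino on an aromatic carbon. Among the measured compounds shown here, no measured step exchanges dimethylamino for trifluoromethyl. The step from compound 2 to compound 3 shows two different groups at this position giving the same reading, which points toward little movement. For the measured compounds named here, compound 1 carries trifluoromethyl on the same ring and reads higher, but it differs from compound 4 at the core, methyl in place of diethylamino, and no step covers that exchange; its value shows only that a compound bearing trifluoromethyl there reached that level. Compound 4 is therefore expected to give 5% (range 0% to 20%). The expected step is a number 5 percentage points higher from compound 3 to compound 4 (within the scatter), none beyond the scatter.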

Compound 4, a percentage reported as inhibition, at one concentration (the size of the read-out at that concentration, not a potency): 13.3%
Estimate against measurement, compound 4: 8.3 percentage points below; the range from low to high includes it.
By their numbers in this assay, from the lowest: compounds 2 and 3 (each within the scatter of the next); then compounds 4 and 1 (each within the scatter of the next).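

On the shared core carrying diethylamino, the earlier pair had shown two groups at this place, on an aromatic carbon ortho to a large group, with no separation, but trifluoromethyl breaks that level reading in this assay: the exchange for dimethylamino gives a number 13.3 percentage points higher from compound 3 to compound 4 (beyond the scatter), and the exchange for trifluoromethoxy gives a number 13.3 percentage points higher from compound 2 to compound 4 (beyond the scatter), so the place does respond to the group it carries, if only modestly. The other place on the core now has a reading as well, since with trifluoromethyl held constant, diethylamino in place of methyl gives a number 7.8 percentage points lower from compound 1 to compound 4 (within the scatter), and that exchange does not separate the two compounds. No available evidence accounts for the gap between trifluoromethyl and trifluoromethoxy at this place.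

The compounds shown leave open whether other groups at this place, such as a chlorine atom, a methyl group or a nitrile, would match trifluoromethyl or stay with dimethylamino and trifluoromethoxy. They also leave open what a longer chain or a cyclic amine in place of diethylamino on the core would do, and each reading, taken at a single concentration, gives no potency.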